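Replacing nitro with acetamido: compound 3 to compound 4

The source may report more compounds than this note shows. Statements on the series, on what has been measured and on what is new or still open speak of the compounds shown alone.

Of the compounds shown here, three of one series have been read in an ADME assay on L02 cells (Homo sapiens) for cytotoxicity, read by MTT assay, with a stated time of 24 h; a lower number here means a stronger inhibitor, a higher number a weaker inhibitor. Compound 1 `CN1C/C(=C\c2cccnc2)C(=O)/C(=C/c2ccccc2F)C1` gives 15900 nM. For compound 2 `O=C1/C(=C/c2cccnc2)CN(S(=O)(=O)c2ccc([N+](=O)[O-])cc2)C/C1=C\c1ccccc1F` the assay reports only a limit, > 20000 nM, and not a number. Compound 3 `O=C1/C(=C/c2ccncc2)CN(S(=O)(=O)c2ccc([N+](=O)[O-])cc2)C/C1=C\c1ccccc1F` gives 18400 nM, which lies within the scatter of the value of compound 1. The ceiling stays in view for whatever follows, with the limit of > 20000 nM in this assay, at which 1 of the 3 values shown sits.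

Compound 4 `CC(=O)Nc1ccc(S(=O)(=O)N2C/C(=C\c3ccncc3)C(=O)/C(=C/c3ccccc3F)C2)cc1` keeps the shared core of compound 3 and has acetamido in place of nitro on an aromatic carbon, para to a large group: acetamido in place of nitro on an aromatic carbon. For the measured compounds named here, only one measured step is available to lean on, an at least 1.0-fold lower number from compound 2 to compound 3 (0.03 log units; that floor lies within the scatter), and its floor lies within the scatter. That step swaps pyridin-3-yl for pyridin-4-yl and leaves the nitro untouched, so it bears on the new change only indirectly. Going by the values given here, it shows a series that has so far moved little in this assay, and no measured step covers the exchange of nitro itself. No shift beyond the scatter is therefore expected, in either direction, and the expected change is a 1.1-fold lower number from compound 3 to compound 4 (0.03 log units; within the scatter). For compound 4 the estimated value is 17000 nM, within an expected range of 8500 nM to 30000 nM.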

Compound 4, half-maximal inhibitory concentration: 12300 nM
Beside the measured number, compound 4's estimate is 1.4-fold (0.14 log units) above it; the measured number falls inside the stated range.
By their numbers in this assay, from the lowest: compounds 4, 1 and 3 (each within the scatter of the next). At a limit, above all of these: compound 2.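

In this assay, the exchange at this position gives a 1.5-fold lower number from compound 3 to compound 4 (0.17 log units; within the scatter), so on an aromatic carbon para to a large group, nitro and acetamido cannot be told apart in this read-out. For the compounds shown here, the one earlier step exchanged pyridin-3-yl for pyridin-4-yl with nitro left in place, so this is the only reading of the 4-nitrophenyl group itself, and it shows that 4-acetamidophenyl, which brings a hydrogen-bond donor that nitro lacks, gives a result within the scatter of the nitro compound. Compound 2 remains a limit and not a number: the limit of > 20000 nM in this assay, at which 1 of the 4 values shown sits.

The compounds shown leave open whether any group at this position can shift the number beyond the scatter, for instance an amine or a carboxylic acid in place of acetamido, or a longer acyl chain on the same nitrogen. They also leave open whether the exchange of nitro for acetamido would read the same with pyridin-3-yl in place of pyridin-4-yl, since the only compound shown with that pairing and nitro, compound 2, stands at the limit.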